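The compounds below may be only part of what the source reports. "The series", "measured", "known", "first", "only" and "open" are said of these compounds alone.

Compound 1 `CC(C)CSc1nc(N)nc2c1ncn2/C=C1/CC1(CO)CO`: in an ADME assay on HFF cells (Homo sapiens) for cytotoxicity, with a stated time of 8 days (on this read-out lower numbers stand for higher toxicity in this test and higher numbers for lower toxicity in this test), compound 1 gives > 300000 nM, which is a limit of the assay and not a number.
Compound 2 `Nc1nc(NC2CCCCC2)c2ncn(/C=C3/CC3(CO)CO)c2n1`: in this assay compound 2 gives > 300000 nM, again a limit.
Compound 3 `CSc1nc(N)nc2c1ncn2/C=C1/CC1(CO)CO`: in this assay compound 3 gives > 300000 nM, also a limit.

Compound 3 therefore stands nowhere on a scale of numbers: its result is a limit, and the two other values shown are limits as well, all three sitting at the limit of > 300000 nM in this assay, at which 3 of the 3 values shown sit. None of the steps between measured compounds can be read: a step that the two limits leave unreadable from compound 1 to compound 2, a step that the two limits leave unreadable from compound 1 to compound 3, and a step that the two limits leave unreadable from compound 2 to compound 3. Compound 4 `CCCCNc1nc(N)nc2c1ncn2/C=C1/CC1(CO)CO` differs from compound 3 in one place: butylamino in place of methylsulfanyl on an aromatic carbon. The steps that touch this change are the exchange of an amino group for a sulfanyl group on the same aromatic carbon, from compound 2 to compound 3, and the change of chain length on the sulfur, from compound 1 to compound 3; both are unreadable, so no size or direction can be taken from them. With every measured compound at the same limit, the expectation for compound 4 is another limit, and the step that the limit leaves unreadable from compound 3 to compound 4 is expected to be none beyond the scatter. For compound 4 the estimate in this assay is 400000 nM, with a range from 150000 nM to 1000000 nM.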

Compound 4, half-maximal cytotoxic concentration: > 300000 nM
Compound 4 ended at the assay's limit (the forecaster's own chance of this, stated with the estimate: 85%); the middle value is on the limit's open side.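

In this assay compound 4 gives > 300000 nM, which is a limit and not a number. No new step can be read between compound 4 and compound 1, compound 2 or compound 3, as all four share one limit: the limit of > 300000 nM in this assay, at which 4 of the 4 values shown sit. The compounds shown leave open whether the groups exchanged on the aromatic carbon differ at all in this assay, and how far any compound lies beyond the limit.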